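A few compounds are considered here, and "the series" means these few. Any claim that something is new, unique, unknown or untested is made for them only; others in the source may bear on it.

Working notes on the series.

The measured set comprises compound 1 `CCN(Cc1cc[nH]n1)C(=O)COc1ccc(C)cc1`, compound 2 `CCN(Cc1ccoc1)C(=O)COc1ccc(C)cc1` and compound 3 `CCN(Cc1cncs1)C(=O)COc1ccc(C)cc1`, all sharing one core and differing only in the five-membered ring on the saturated chain carbon bound to the amide-type nitrogen. In an assay on HEK293 cells for agonist activity at transient receptor potential cation channel subfamily M member 8 (Homo sapiens), read by fluorescence and calcium flux, with a stated time of 15 min (a higher number here means that more compound is needed for the effect, a lower number that less compound is needed), compound 1 is reported as "not active" (no number reported), compound 2 gives 136 nM and compound 3 gives 1100 nM. On the numbers shown, compound 3 stands highest of the two values, with compound 2 nearest; the only single-place step recorded is an 8.1-fold higher number from compound 2 to compound 3 (0.91 log units; beyond the scatter).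

The next compound is compound 4 `CCN(Cc1cc[nH]c1)C(=O)COc1ccc(C)cc1`. Its difference from compound 3 is 1H-pyrrol-3-yl in place of 1,3-thiazol-5-yl on a saturated chain carbon bound to an amide-type nitrogen. Among the measured compounds shown here, no measured step carries a ring with a hydrogen-bond donor into a numbered value: compound 1, which also carries such a donor, is reported only as not active, and the one quantified step goes the other way, from furan-3-yl to 1,3-thiazol-5-yl. The step from compound 3 to compound 4 in this assay is therefore expected to be a 2.3-fold higher number from compound 3 to compound 4 (0.36 log units; beyond the scatter), a weakening beyond the scatter, with a real chance that no number is returned. Compound 4 is estimated at 2500 nM, within 600 nM to 10000 nM.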

Compound 4, half-maximal effective concentration: 21800 nM
Compound 4: middle estimate off by 8.7-fold (0.94 log units), on the low side, and the stated range ends below it.
By their numbers in this assay, from the lowest: compound 2; then compound 3; then compound 4.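

In this assay, among the compounds shown here, the ring on the saturated chain carbon bound to an amide-type nitrogen now has a numbered value with a hydrogen-bond donor, and the change is far larger than anything seen before: a 20-fold higher number from compound 3 to compound 4 (1.30 log units; beyond the scatter) and a 160-fold higher number from compound 2 to compound 4 (2.20 log units; beyond the scatter) stand against the earlier 8.1-fold higher number from compound 2 to compound 3 (0.91 log units; beyond the scatter) as the only quantified change. For the compounds shown here, this position therefore separates rings of equal heavy-atom count widely, with 1H-pyrrol-3-yl at the high end of the numbered set, while compound 1, the other ring with such a donor, gives "not active" (no number reported), so that no step involving it can be read. The two donor-carrying rings thus both sit poorly in this assay, though nothing shown explains the size of these steps and nothing separates the donor from the identity of the ring.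

Open, on these data alone, is whether a 1-methylpyrrol-3-yl ring, with a methyl group on the ring nitrogen, returns to the range of compound 2 or stays with compound 4. Also open, as far as these compounds go, is whether a phenyl ring at this place, or a propyl chain in place of the ethyl group on the amide-type nitrogen, keeps the same order among the rings.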